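Swapping the ketone aryl group in a thiazole nitrile series

This account rests on a few compounds, and the source may have more. Where it says the series, first, only, none or still open, it means among the compounds named here.

The two compounds measured here share a common core and differ at two places. Compound 1, `Cc1cc(C(=O)c2cnc(Nc3cccc(C(F)(F)F)c3)s2)c(C)s1`, carries a trifluoromethyl on the aniline side and a 2,5-dimethylthiophen-3-yl on the carbonyl carbon; in an assay for inhibition of Neuropeptide Y receptor type 5 (Mus musculus) (a lower number here means a stronger inhibitor, a higher number a weaker inhibitor), compound 1 gives 395 nM. Compound 2, `CCc1ccccc1C(=O)c1cnc(Nc2cccc(C#N)c2)s1`, carries a nitrile on the aniline side and a 2-ethylphenyl on the carbonyl carbon; in this assay compound 2 gives 2.8 nM, the lowest of the two numbers and far beyond the scatter from compound 1.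

Compound 3, `Cc1cc(C(=O)c2cnc(Nc3cccc(C#N)c3)s2)c(C)s1`, keeps the nitrile of compound 2 and takes the ketone aryl group of compound 1: 2,5-dimethylthiophen-3-yl in place of 2-ethylphenyl on a carbonyl carbon. For the measured compounds named here, no single-change step is available to gauge this exchange, and compound 3 differs at the aniline side as well from compound 1, whose value of 395 nM is only a loose anchor. The expectation for compound 3 is a clear weakening relative to compound 2, a 14-fold higher number from compound 2 to compound 3 (1.15 log units; beyond the scatter), though not all the way to compound 1. Compound 3 is therefore estimated at 40 nM in this assay, within a range of 8 nM to 200 nM.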

Compound 3, half-maximal inhibitory concentration: 14 nM
The estimate for compound 3 lay 2.9-fold (0.46 log units) above the measured number, and the stated range covers the measured number.
By their numbers in this assay, from the lowest: compound 2; then compound 3; then compound 1.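

Compound 3 separates the two changes that compounds 1 and 2 carried together. With the nitrile held fixed, 2,5-dimethylthiophen-3-yl in place of 2-ethylphenyl on a carbonyl carbon gives a 5.0-fold higher number from compound 2 to compound 3 (0.70 log units; beyond the scatter) in this assay, while with the ketone aryl group held fixed, cyano in place of trifluoromethyl on an aromatic carbon gives a 28-fold lower number from compound 1 to compound 3 (1.45 log units; beyond the scatter) in the same measurement, so both changes contribute and the second is the larger of the two in this pair of steps. Nothing available here accounts for either step, so the numbers describe their size and direction but give no reason for them.

On these data alone, each step is read against only one partner, the ketone exchange with the nitrile and the aniline-side exchange with 2,5-dimethylthiophen-3-yl, so it remains open whether either would keep its size with the other group in place. Also open, as far as these compounds go, is how other groups would behave at these two places, for instance a methoxy or a chlorine in place of the nitrile, or an unsubstituted phenyl or a 2-methylphenyl on the carbonyl carbon.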